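This account rests on a few compounds, and the source may have more. Where it says the series, first, only, none or still open, it means among the compounds named here.

Compound 2 `Cc1cn(Cc2ccc(Cl)cc2Cl)c2c(-c3nnc(NS(=O)(=O)c4ccc(Cl)c(Cl)c4)o3)cc(F)cc12` and compound 1 `Cc1cn(Cc2ccc(Cl)cc2Cl)c2c(-c3nnc(NS(=O)(=O)c4cc(F)c(F)cc4F)o3)cc(F)cc12` share one core and differ only in the aryl group carried by the sulfonyl sulfur. In an assay on isolated protein with thromboxane A2 receptor (Homo sapiens) as the target, read by FLIPR, tested at 1 uM (a lower number here means a weaker effect, a higher number a stronger effect of the compound at the concentration tested), compound 1 gives 11%, while compound 2 gives 0%. For the measured compounds named here, compound 2 thus stands lowest of the two numbers, with compound 1 its nearest neighbour, and the one measured step, a number 11 percentage points lower from compound 1 to compound 2 (beyond the scatter), shows the size of that gap. Compound 3 `Cc1cn(Cc2ccc(Cl)cc2Cl)c2c(-c3nnc(NS(=O)(=O)c4ccc(F)c(F)c4)o3)cc(F)cc12` has not yet been measured; it differs from compound 2 in one place: 3,4-difluorophenyl in place of 3,4-dichlorophenyl on a sulfonyl sulfur. Going by the values given here, only the step from compound 1 to compound 2 bears on this change, since both swaps exchange chlorine and fluorine on the ring carried by the sulfonyl sulfur, though that earlier swap also altered the substitution pattern. A small rise is therefore expected, a number 6 percentage points higher from compound 2 to compound 3 (within the scatter), within or only just beyond the usual scatter. Compound 3 is estimated at 6%, with a range from 0% to 20%.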

Compound 3, a percentage reported as activity, at one concentration (the size of the read-out at that concentration, not a potency): 9%
For compound 3 the middle estimate is 3 percentage points below the measured one, and the stated range covers the measured number.
By their numbers in this assay, from the lowest: compounds 2, 3 and 1 (each within the scatter of the next, the first and the last beyond it).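

On the ring carried by the sulfonyl sulfur, 3,4-difluorophenyl in place of 3,4-dichlorophenyl gives a number 9 percentage points higher from compound 2 to compound 3 (within the scatter) in this assay, so this exchange of halogen alone cannot be told from the usual scatter. Hydrogen in place of fluoro on an aromatic carbon gives a number 2 percentage points lower from compound 1 to compound 3 (within the scatter), so the extra fluoro of compound 1 has no effect that can be read here. Only compound 1 and compound 2 lie beyond the scatter of each other, and nothing available explains any of these numbers.

Every aryl group shown carries only halogens, so a phenyl ring bearing a methoxy group, a nitrile or a carboxylic acid remains open. So does a plain alkyl group such as methyl on the sulfonyl sulfur.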